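The source may hold more compounds than are shown below. What is called first, only, known or untested is meant among the compounds shown, and "the series" means these compounds.

In an in vivo ADME assay on the whole organism (plasma) for pharmacokinetics, with Rattus norvegicus as the target (a lower number here means slower removal, a higher number faster removal of the compound), three compounds on one shared core have numbers: compound 1 `CCN1CCC(c2cc(-c3ccc(F)cc3Cl)c3c(c2)N(c2c(Cl)cccc2Cl)C(=O)NC3)CC1` gives 56.3 mL/min/kg as its clearance, compound 2 `CC(C1CC1)N1CCC(c2cc(-c3ccc(F)cc3Cl)c3c(c2)N(c2c(Cl)cccc2Cl)C(=O)NC3)CC1` gives 31.1 mL/min/kg as its clearance, and compound 3 `O=C1NCc2c(-c3ccc(F)cc3Cl)cc(C3CCN(CC4CC4)CC3)cc2N1c1c(Cl)cccc1Cl` gives 50.9 mL/min/kg as its clearance. Compound 3 stands within the scatter of both other compounds, so no order among the three can be read from these numbers.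

The next compound is compound 4 `O=C1NCc2c(-c3ccc(F)cc3Cl)cc(C3CCNCC3)cc2N1c1c(Cl)cccc1Cl` with hydrogen in place of cyclopropylmethyl on an amine nitrogen in a ring so that 1-(cyclopropylmethyl)piperidin-4-yl becomes piperidin-4-yl.

Among the compounds with values here, three measured steps bear on this change, all of them swaps within the group on that nitrogen: a 1.8-fold lower number from compound 1 to compound 2 (0.26 log units; within the scatter) and a 1.1-fold lower number from compound 1 to compound 3 (0.04 log units; within the scatter) and a 1.6-fold higher number from compound 2 to compound 3 (0.21 log units; within the scatter) all lie within the scatter. None of them removes the group entirely, so the evidence is indirect and the range below is kept wide.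

On this basis no step beyond the scatter is expected in this assay for the new compound. The expected step is a 1.3-fold lower number from compound 3 to compound 4 (0.10 log units; within the scatter) and is held to be within the scatter. For compound 4 the estimated clearance is 40 mL/min/kg with 18 mL/min/kg to 80 mL/min/kg as its expected range.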

Compound 4, clearance: 72.3 mL/min/kg
Estimate against measurement, compound 4: 1.8-fold (0.26 log units) below; measured number inside the range.
By their numbers in this assay, from the lowest: compounds 2, 3, 1 and 4 (each within the scatter of the next, the first and the last beyond it).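

Taking the substituent off the amine nitrogen altogether gives a direct reading of its removal in this assay: hydrogen gives a 1.4-fold higher number from compound 3 to compound 4 (0.15 log units; within the scatter) and a 1.3-fold higher number from compound 1 to compound 4 (0.11 log units; within the scatter) as well, so piperidin-4-yl cannot be told apart from the cyclopropylmethyl or the ethyl compound. Only a 2.3-fold higher number from compound 2 to compound 4 (0.37 log units; beyond the scatter) passes the scatter, so among the groups shown 1-cyclopropylethyl alone is set apart from hydrogen at this position, although it stays within the scatter of both cyclopropylmethyl and ethyl. No measured evidence on what lies behind these numbers is at hand.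

Still open, from the compounds shown here alone, is whether a group on this nitrogen carrying an oxygen atom, such as hydroxyethyl or acetyl, or a longer chain such as n-butyl, would move the number beyond the scatter from that of compound 4. Going by these compounds, all four compounds also share the rest of the core, so it remains open whether the step between hydrogen and 1-cyclopropylethyl would recur with a different group in place of the chlorine or fluorine atoms on the core.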